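This account rests on a few compounds, and the source may have more. Where it says the series, first, only, none or still open, it means among the compounds named here.

Of the compounds shown here, two of a shared core have been measured in a functional assay on NCI/ADR-RES cells (Homo sapiens) for inhibition, read by sulforhodamine B assay, with a stated time of 48 h, tested at 10 uM; a higher number here means a weaker effect of the compound at the concentration tested, a lower number a stronger effect. Going by the values given here, compound 1, `COc1cc(Cl)cc(-c2nn(-c3cccc(NC(=O)c4ccc(Cl)c(Cl)c4)c3)cc2-c2ccncc2)c1`, carries a 3,4-dichlorophenyl on its carbonyl carbon; in this assay compound 1 gives 61.4%, the highest of the two numbers so far, which here means the weaker effect. Compound 2, `COc1cc(Cl)cc(-c2nn(-c3cccc(NC(=O)Nc4cc(C(F)(F)F)cc(C(F)(F)F)c4)c3)cc2-c2ccncc2)c1`, is built differently in more than one place; in this assay compound 2 gives 2.37%, a number far below that of compound 1 and beyond the scatter. The two measured compounds differ in several places at once. The gap between them cannot be tied to any single part of the structure.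

Compound 3, `COc1cc(Cl)cc(-c2nn(-c3cccc(NC(=O)c4cccc(C(F)(F)F)c4)c3)cc2-c2ccncc2)c1`, has not yet been measured. It differs from compound 1 in one place: 3-(trifluoromethyl)phenyl in place of 3,4-dichlorophenyl on a carbonyl carbon. Nothing measured shows how a 3-(trifluoromethyl)phenyl behaves on the carbonyl carbon, so the expectation leans on compound 1 alone. A modest move toward a stronger effect is expected, a number 11.4 percentage points lower from compound 1 to compound 3 (beyond the scatter), though a step of this size could fall within the scatter. Compound 3 is therefore expected to give about 50% in this assay, with a range from 15% to 85%.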

Compound 3, a percentage reported as activity, at one concentration (the size of the read-out at that concentration, not a potency): 46.7%
Estimate against measurement, compound 3: 3.3 percentage points above, within the range that was stated.
By their numbers in this assay, from the lowest: compound 2; then compound 3; then compound 1.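

Going by these compounds alone, compound 3 provides the first comparison here that changes one place only, and in this assay the swap on the carbonyl carbon gives a number 14.7 percentage points lower from compound 1 to compound 3 (beyond the scatter) and so a modestly stronger effect at the one concentration tested. This shows that the position is not indifferent to the group it carries: replacing 3,4-dichlorophenyl with 3-(trifluoromethyl)phenyl, with the rest of the molecule unchanged, moves the read-out by more than the usual scatter. Both groups are aromatic rings of carbon only and have no hydrogen-bond donors or acceptors, and nothing measured here explains why the number moves.

The compounds shown leave open how this carbonyl carbon would respond to quite different groups, such as a phenyl ring bearing a carboxylic acid or an amine, or a longer alkyl chain in place of the ring. Compound 2 also still differs from compound 1 and compound 3 in more than one place, so its result cannot be assigned to any single structural change.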